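This account rests on a few compounds, and the source may have more. Where it says the series, first, only, none or still open, it means among the compounds named here.

Measured in a functional assay on SW480 cells (Homo sapiens) for antiproliferative activity, read by MTT assay, with a stated time of 48 h; on this read-out higher numbers stand for weaker inhibition and lower numbers for stronger inhibition:
compound 1 `CCCCCCC(CCO)n1c(Br)nc2c(Cl)ncnc21` gives 14100 nM
compound 2 `CCCCCCCC(CCO)n1c(Br)nc2c(Cl)ncnc21` gives 14400 nM
compound 3 `CCCCCCCCC(CCO)n1cnc2c(Cl)ncnc21` gives 1370 nM

Compound 3 has the lowest of these three numbers, and its gap to each of the other two lies beyond the scatter. The next compound to consider is compound 4 `CCCCCCCCC(CCO)n1c(Br)nc2c(Cl)ncnc21`, which differs from compound 3 by one change: bromo in place of hydrogen on an aromatic carbon. In words, a bromo group takes the place of a hydrogen on an aromatic carbon.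

For the measured compounds named here, no measured step isolates this change. Going by the values given here, the only measured step, a 1.0-fold higher number from compound 1 to compound 2 (0.01 log units; within the scatter), concerns the saturated chain and shows no change beyond the scatter. Compound 1 and compound 2 both carry the bromo group that compound 4 gains, and both have numbers well above that of compound 3. This points to a clear rise, meaning weaker inhibition, though the evidence is indirect. The expected change is a 7.3-fold higher number from compound 3 to compound 4 (0.86 log units; beyond the scatter). Compound 4 is expected to give about 10000 nM, with an estimated range of 4000 nM to 20000 nM.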

Compound 4, half-maximal inhibitory concentration: 17800 nM
The estimate for compound 4 lay 1.8-fold (0.25 log units) below the measured number, within the range that was stated.
By their numbers in this assay, from the lowest: compound 3; then compounds 1, 2 and 4 (each within the scatter of the next).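

In this assay, for the compounds shown here, the direct step of a 13-fold higher number from compound 3 to compound 4 (1.11 log units; beyond the scatter) shows that bromo in place of hydrogen on this aromatic carbon, between two ring nitrogen atoms, goes with much weaker inhibition, a large loss that the earlier compounds could only hint at. With bromo present, the chain differences matter little: the methyl step a 1.2-fold higher number from compound 2 to compound 4 (0.09 log units; within the scatter) and the ethyl step a 1.3-fold higher number from compound 1 to compound 4 (0.10 log units; within the scatter) both lie within the scatter, so the chain changes shown do not offset the loss that comes with bromo.

Still open, going by these compounds, is how other groups on this carbon, such as chloro, methyl or an amine, would compare with hydrogen, and whether shorter chains would give similar numbers with hydrogen there. Nothing measured here gives a reason for the large step seen with bromo.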